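The compounds below may be only part of what the source reports. "The series", "measured", "known", "first", "only" and "open" are said of these compounds alone.

Measured so far in a functional assay on HCT-116 cells (Homo sapiens) for antiproliferative activity, read by MTT assay, with a stated time of 48 h; a higher number here means a weaker inhibitor, a lower number a stronger inhibitor:
- compound 1 `CCCCCC(CCO)n1cnc2c(N)ncnc21`: > 50000 nM (a limit of the assay, not a number)
- compound 2 `CCCCCCCCCCC(CCO)n1cnc2c(NC)ncnc21`: 12700 nM

Among the measured compounds shown here, compound 2, at 12700 nM, holds the only actual number so far in this assay. The second result is the limit reached by compound 1, so there is little to compare it with.

Compound 3 `CCCCCCCCCCC(CCO)n1cnc2c(N)ncnc21` keeps the long chain of compound 2 and changes only the group on the core: hydrogen in place of methyl on a nitrogen on an aromatic ring. This places hydrogen in place of methyl on a nitrogen on an aromatic ring, turning methylamino to amino.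

For the measured compounds named here, no measured pair isolates this change, because compound 1 and compound 2 differ in their chains as well. A small step is therefore expected, with no firm direction and perhaps none beyond the usual scatter. The expected step is a 1.2-fold lower number from compound 2 to compound 3 (0.06 log units; within the scatter).

For compound 3 the estimated value is 11000 nM, with an expected range of 4500 nM to 30000 nM.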

Compound 3, half-maximal inhibitory concentration: 2590 nM
Compound 3: the middle estimate sits 4.2-fold (0.63 log units) above what was measured; measured number outside the range, below it.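

In this assay, the change from methylamino to amino on the core gives a 4.9-fold lower number from compound 2 to compound 3 (0.69 log units; beyond the scatter), so even this single methyl on a nitrogen on an aromatic ring matters, and the compound without it is the stronger of the pair. Among the compounds shown here, compound 3 also gives the first comparison of chains alone, with pentyl in place of hydrogen on a saturated chain carbon, six bonds along the chain from an aromatic nitrogen, showing an at least 19-fold lower number from compound 1 to compound 3 (1.28 log units; beyond the scatter). The value of compound 1 in that comparison is a limit of the assay, not a number: the limit of > 50000 nM in this assay, at which 1 of the 3 values shown sits.

With only hydrogen and methyl shown on this nitrogen, it remains open how an ethyl group or an acetyl group there would fare. On these data alone, it is also open whether a longer chain would lower the number further or raise it again.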